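A few compounds are considered here, and "the series" means these few. Any claim that something is new, unique, unknown or untested is made for them only; others in the source may bear on it.

Compound 1 `COc1cc(-c2cnn3cc(OC)c(C(C)C)nc23)ccn1` gives 40%
Compound 2 `COc1cn2ncc(-c3ccnc(OC(C)(C)C)c3)c2nc1-c1cnn(C)c1` gives 35%

Within the data shown here, only two compounds have been measured so far, both in an ADME assay on microsomes from liver (Homo sapiens) for metabolic stability, with a stated time of 60 min, tested at 1 uM; a lower number here means that less of the compound is left, a higher number that more of the compound is left. Compound 1 reads 40% and compound 2 reads 35% so the two lie within the usual scatter of each other and cannot be ranked. Among the measured compounds shown here, compound 1 therefore stands level with the only other number available, and this leaves a good part of it gone by the end of the test.

Compound 3 `COc1cc(-c2cnn3cc(OC)c(C4CCCC4)nc23)ccn1` has not yet been measured. It keeps the core of compound 1 and differs in a single place, with cyclopentyl in place of isopropyl on an aromatic carbon. The group that enters is larger and brings a five-membered non-aromatic ring of carbon only.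

For the measured compounds named here, no two measured compounds differ in just one place, so the data offer no direct guide to this change, and any forecast is a judgement with wide margins. A moderate fall in this assay is expected, and the estimated size is a number 13 percentage points lower from compound 1 to compound 3 (beyond the scatter) in this reading. For compound 3 the estimated value is 27% with an expected range from 10% to 48% in this test.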

Compound 3, percent of the compound remaining: 32%
Beside the measured number, compound 3's estimate is 5 percentage points below it; the measured number falls inside the stated range.
By their numbers in this assay, from the lowest: compounds 3, 2 and 1 (each within the scatter of the next).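

In this assay, among these compounds, the exchange of isopropyl for cyclopentyl on this aromatic carbon gives the first direct reading at this position, and it comes out as a number 8 percentage points lower from compound 1 to compound 3 (within the scatter). So, for this one pair on the core of compound 1, adding a five-membered non-aromatic ring of carbon only in place of the open isopropyl group leaves no difference that can be told from the usual variation between repeat measurements. Nothing available explains this result or shows what happens to either compound in the microsomes.

On these data alone, a single step within the scatter says little about the position as a whole, so it remains open whether a much smaller group such as methyl, or a ring that carries oxygen or nitrogen such as morpholine, would move the number by a readable amount. As far as these compounds go, it is also open whether an amine or a longer carbon chain at this position would behave like cyclopentyl or would give a clear step in either direction.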